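Chloro for methoxy on the aryl of compound 2

A few compounds are considered here, and "the series" means these few. Any claim that something is new, unique, unknown or untested is made for them only; others in the source may bear on it.

Measured so far:
compound 1, `O=C(/C=C/c1cccc(O)c1)c1cccc(-n2cc(-c3ccc(Cl)cc3)[nH]c2=O)c1`: 2520 nM
compound 2, `COc1ccc(-c2cn(-c3cccc(C(=O)/C=C/c4ccc(O)c(OC)c4)c3)c(=O)[nH]2)cc1`: 8200 nM

In a functional assay on NCI-H322M cells (Homo sapiens) for inhibition (a higher number here means a weaker inhibitor of growth, a lower number a stronger inhibitor of growth), compound 2 gives 8200 nM, the highest of the two numbers measured. Its nearest neighbour is compound 1, which in this assay gives 2520 nM, a difference that lies beyond the usual scatter. Within the data shown here, compound 1 and compound 2 differ in more than one place, so no single step between them can be read off; only the two values themselves can be compared.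

Compound 3, `COc1cc(/C=C/C(=O)c2cccc(-n3cc(-c4ccc(Cl)cc4)[nH]c3=O)c2)ccc1O`, has not yet been measured. It differs from compound 2 in one place only: chloro in place of methoxy on an aromatic carbon. Compound 3 thus carries the same 4-chlorophenyl group as compound 1, while keeping the rest of compound 2 unchanged. Since compound 1 with its chloro group gives 2520 nM and compound 2 with its methoxy group gives 8200 nM, compound 3 is expected to move toward the lower number, with a step from compound 2 to compound 3 of about a 2.3-fold lower number from compound 2 to compound 3 (0.37 log units; beyond the scatter) in this assay. For compound 3 the estimated value in this assay is 3500 nM, with a range from 1500 nM to 9000 nM.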

Compound 3, concentration for 50% growth inhibition: 4580 nM
Compound 3: the middle estimate sits 1.3-fold (0.12 log units) below what was measured; the measured number falls inside the stated range.
By their numbers in this assay, from the lowest: compounds 1, 3 and 2 (each within the scatter of the next, the first and the last beyond it).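

In this assay, chloro in place of methoxy on an aromatic carbon, para to a large group, gives a 1.8-fold lower number from compound 2 to compound 3 (0.25 log units; within the scatter) and so lies within the scatter: with the rest of compound 2 unchanged, 4-chlorophenyl and 4-methoxyphenyl are not told apart at this position. The change on the other side, 4-hydroxy-3-methoxyphenyl in place of 3-hydroxyphenyl on the double-bonded chain, gives a 1.8-fold higher number from compound 1 to compound 3 (0.26 log units; within the scatter) and also stays within the scatter. Each of the two single changes now stands on its own, and neither gives a step beyond the scatter, while no measurement at hand bears on the reason for either step.

Among these compounds, only one exchange has been read at each of these two places, so it remains open whether an amine, a carboxylic acid or a longer chain on that phenyl ring would give a step beyond the scatter. As far as these compounds go, it is also open whether chloro in place of methoxy would give a step of the same size with the 3-hydroxyphenyl group on the chain.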